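Swapping 4-hydroxyphenyl for 3-chlorophenyl on a shared core

The source may hold more compounds than are shown below. What is called first, only, known or untested is meant among the compounds shown, and "the series" means these compounds.

Three compounds have been measured in a functional assay on MGC-803 cells (Homo sapiens) for cytotoxicity, read by MTT assay, with a stated time of 72 h; a higher number here means a weaker inhibitor, a lower number a stronger inhibitor:
Compound 1 `O=C1C(=Cc2ccc(O)cc2)C(=O)N(c2ccc(Cl)cc2)N1c1ccc(Cl)cc1`: 19500 nM
Compound 2 `O=C1C(=Cc2ccc(F)cc2)C(=O)N(c2ccc(Cl)cc2)N1c1ccc(Cl)cc1`: 26000 nM
Compound 3 `O=C1C(=Cc2ccc(Br)cc2)C(=O)N(c2ccc(Cl)cc2)N1c1ccc(Cl)cc1`: 16900 nM

Compound 1 stands among these values without separating from either neighbour, as a 1.3-fold higher number from compound 1 to compound 2 (0.12 log units; within the scatter) and a 1.2-fold lower number from compound 1 to compound 3 (0.06 log units; within the scatter) both stay within the scatter. The remaining pair behaves the same way, with a 1.5-fold lower number from compound 2 to compound 3 (0.19 log units; within the scatter) also within the scatter. Across hydroxy, fluoro and bromo, then, this small set shows no real change in this assay.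

Compound 4 `O=C1C(=Cc2cccc(Cl)c2)C(=O)N(c2ccc(Cl)cc2)N1c1ccc(Cl)cc1` has 3-chlorophenyl in place of 4-hydroxyphenyl on a double-bonded chain carbon bound to a double-bonded ring carbon, and the rest of the structure of compound 1 is kept: 3-chlorophenyl in place of 4-hydroxyphenyl on a double-bonded chain carbon bound to a double-bonded ring carbon. The three measured steps bear on this change only in part. Going by the values given here, they exchange one substituent on an aromatic carbon for another, but none of the measured compounds carries the 3-chlorophenyl, so that group itself remains untested. Given the flat steps above, no shift beyond the scatter is expected, and the expected step is a 1.0-fold higher number from compound 1 to compound 4 (0.01 log units; within the scatter). For compound 4 the estimated value is 20000 nM, with an expected range from 10000 nM to 40000 nM.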

Compound 4, half-maximal inhibitory concentration: 14400 nM
The estimate for compound 4 lay 1.4-fold (0.14 log units) above the measured number, and the stated range covers the measured number.
By their numbers in this assay, from the lowest: compounds 4, 3, 1 and 2 (each within the scatter of the next).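

In this assay, going by these compounds alone, every earlier group on the double-bonded chain carbon bound to a double-bonded ring carbon was 4-hydroxyphenyl, 4-fluorophenyl or 4-bromophenyl, so compound 4 is the first to test 3-chlorophenyl at this place, and the exchange for 4-hydroxyphenyl, which also takes away the hydrogen-bond donor and acceptor counted in that group, gives a 1.4-fold lower number from compound 1 to compound 4 (0.13 log units; within the scatter). The comparisons with the other two groups read the same way, with a 1.2-fold lower number from compound 3 to compound 4 (0.07 log units; within the scatter) and a 1.8-fold lower number from compound 2 to compound 4 (0.26 log units; within the scatter), so this position has now accepted a different substituent and a different substitution pattern on the phenyl ring without any step leaving the scatter. No measurement is available to explain why the number stays so flat across these four groups.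

The compounds shown leave open whether a phenyl ring bearing an amine, a carboxylic acid or a longer alkyl chain, or a group other than phenyl at this place, would move the number beyond the scatter. From the compounds shown here alone, it also remains open whether this flat picture would hold if the rest of the shared core, which is identical in all four compounds, were changed.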